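Aryl substituent swaps on the biaryl urea series

The compounds below may be only part of what the source reports. "The series", "measured", "known", "first", "only" and "open" are said of these compounds alone.

Measured so far:
- compound 1 `Cc1ccc(CN2CCC(NC(=O)N(CC(=O)C(C)(C)O)Cc3ccc(-c4ccc(F)cc4)cc3)CC2)cc1`: 5.34 in an in vitro functional assay on HEK293 cells for antagonist activity at melanin-concentrating hormone receptor 1 (Homo sapiens), read by GTPgammaS binding, with a stated time of 45 min; on this read-out lower numbers stand for lower potency and higher numbers for higher potency (the scale is a negative logarithm)
- compound 2 `COc1ccccc1-c1ccc(CN(CC(=O)C(C)(C)O)C(=O)NC2CCN(Cc3ccc(C)cc3)CC2)cc1`: 5.43 in this assay

Compound 2 holds the highest of the two numbers in this assay, but only by a margin that the scatter covers: the step of a number 0.09 log units higher from compound 1 to compound 2 (within the scatter) is within the usual spread. Compound 2 therefore stands level with compound 1, not above it.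

Compound 3 `Cc1ccc(CN2CCC(NC(=O)N(CC(=O)C(C)(C)O)Cc3ccc(-c4cccc(C#N)c4)cc3)CC2)cc1` takes the series one change further. Relative to compound 2, the change is 3-cyanophenyl in place of 2-methoxyphenyl on an aromatic carbon. Among the measured compounds shown here, the single measured step that bears on it is the earlier swap on the same aromatic carbon, a number 0.09 log units higher from compound 1 to compound 2 (within the scatter), which altered the read-out by an amount that lies within the scatter. With one step of that kind available, and no evidence that the aryl group at this position moves the number materially, compound 3 is expected to sit close to compound 2, with a step of a number 0.03 log units lower from compound 2 to compound 3 (within the scatter) expected in this assay, not beyond the scatter in either direction. For compound 3 the estimate in this assay is 5.4, with a range from 4.9 to 5.9.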

Compound 3, negative logarithm of the antagonist equilibrium constant: 5.3
Beside the measured number, compound 3's estimate is 0.10 log units above it, and the stated range covers the measured number.
By their numbers in this assay, from the lowest: compounds 3, 1 and 2 (each within the scatter of the next).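

In this assay, the aryl group on this aromatic carbon, para to a large group, has now been varied a second time, and the 3-cyanophenyl group gives a number 0.13 log units lower from compound 2 to compound 3 (within the scatter) and a number 0.04 log units lower from compound 1 to compound 3 (within the scatter). The three compounds therefore stand level, with none going against that reading: 4-fluorophenyl, 2-methoxyphenyl and 3-cyanophenyl cannot be told apart in this read-out, so the flat picture no longer rests on a single step and now extends to a substituent with a triple bond. No measurement bearing on why the number stays level is available here, so the result gives the size of these steps but no account of them.

The compounds shown leave open whether any group at this position can move the number beyond the scatter, and a carboxylic acid or an aminomethyl group on the phenyl ring, or a longer chain in place of the aryl group, would test this. As all three compounds share the rest of the core, they also say nothing about how much the other parts of the structure contribute to the number.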